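This account rests on a few compounds, and the source may have more. Where it says the series, first, only, none or still open, it means among the compounds named here.

Working notes on the series

Compound 1 `Oc1cccc(-c2cc(-c3ccc(C(F)(F)F)cc3)cc(-c3ccccc3O)n2)c1` carries a 3-hydroxyphenyl on its core. In a functional assay on HeLa cells (Homo sapiens) for inhibition (on this read-out higher numbers stand for weaker inhibition and lower numbers for stronger inhibition), compound 1 returns only a limit, > 50000 nM, not a number. Compound 2 `Oc1ccc(-c2cc(-c3ccc(C(F)(F)F)cc3)cc(-c3ccccc3O)n2)cc1` differs from compound 1 by 4-hydroxyphenyl in place of 3-hydroxyphenyl on an aromatic carbon. In this assay compound 2 likewise returns only a limit, > 50000 nM. The step between them is therefore a step that the two limits leave unreadable from compound 1 to compound 2, which follows from the limit of > 50000 nM in this assay, at which 2 of the 3 values shown sit.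

Among the compounds with values here, compound 3 `Oc1cccc(-c2cc(-c3ccccc3C(F)(F)F)cc(-c3cccc(O)c3)n2)c1` is the one member of the set with a number in this assay: compound 3 gives 15200 nM. How the core of compound 3 differs from the core of compound 1 is not broken down here.

Compound 4 `Oc1ccc(-c2cc(-c3ccccc3C(F)(F)F)cc(-c3cccc(O)c3)n2)cc1` is not yet measured. It differs from compound 3 by 4-hydroxyphenyl in place of 3-hydroxyphenyl on an aromatic carbon. Within the data shown here, this is the same kind of change as the one from compound 1 to compound 2, not the same change: in compound 4 the place is meta to a 2-(trifluoromethyl)phenyl group and meta to a 3-hydroxyphenyl group, whereas in compound 2 the place is meta to a 2-hydroxyphenyl group and meta to a 4-(trifluoromethyl)phenyl group.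

The measured step from compound 1 to compound 2 gives no readable size. For compound 1 and for compound 2 this assay gives only a limit. So the step expected from compound 3 to compound 4 in this assay, a 1.6-fold higher number from compound 3 to compound 4 (0.22 log units; within the scatter), rests only on the starting value of compound 3, 15200 nM. Compound 4 is estimated at 25000 nM in this assay, expected between 8000 nM and 80000 nM, with a real chance that only a limit is reported.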

Compound 4, half-maximal inhibitory concentration: 17400 nM
Estimate against measurement, compound 4: 1.4-fold (0.16 log units) above; the measured number falls inside the stated range.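

On the core of compound 3, this assay gives a 1.1-fold higher number from compound 3 to compound 4 (0.06 log units; within the scatter), so 4-hydroxyphenyl and 3-hydroxyphenyl at this place cannot be told apart on this core in this read-out. Within the data shown here, compound 1 and compound 2 both return only limits, not numbers, so the same kind of change on their core cannot be read, and the only readable step cannot be set against a second one: the limit of > 50000 nM in this assay, at which 2 of the 4 values shown sit. This leaves the result as a single observation on one core: it does not show that the change is equally silent on the core of compound 1, and it says nothing about how the change would behave on any other core.

The compounds shown leave open whether any replacement at this place would move the number beyond the scatter, since both groups compared here are hydroxyphenyl groups; a plain phenyl, an aminophenyl or a phenyl carrying a carboxylic acid would test this. Also open, going by these compounds, is what separates the core of compound 3 from the core of compound 1, as these two compounds differ in more than one place and no single change between them can be isolated.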